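Amide-linked quinoline series: extending the amino side chain

This account rests on a few compounds, and the source may have more. Where it says the series, first, only, none or still open, it means among the compounds named here.

Measured so far:
compound 1 `CCNc1cc(C)c2cc(NC(=O)c3ccc(Cl)c(Cl)c3)ccc2n1`: 28200 nM
compound 2 `CCN1CCN(c2cc(C)c3cc(NC(=O)c4cc(Cl)cc(Cl)c4)ccc3n2)CC1`: 2660 nM

In a functional assay on SK-BR-3 cells (Homo sapiens) for antiproliferative activity, read by MTT assay, with a stated time of 72 h (a higher number here means a weaker inhibitor, a lower number a stronger inhibitor), compound 1 gives the highest of the two numbers shown, with compound 2 an order below it; compound 2 differs from compound 1 in more than one place, so no single step between them is drawn. Compound 3 `Cc1cc(NCCN2CCCCC2)nc2ccc(NC(=O)c3ccc(Cl)c(Cl)c3)cc12` is unmeasured. It differs from compound 1 by piperidin-1-yl in place of hydrogen on a saturated chain carbon, two bonds along the chain from a nitrogen on an aromatic ring. Within the data shown here, with no measured step of this exact kind, a moderate expected step of a 3.1-fold lower number from compound 1 to compound 3 (0.50 log units; beyond the scatter) toward a lower number is taken, in the direction that compound 2 points with 2660 nM. For compound 3 the estimate is 9000 nM, within 2500 nM to 30000 nM.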

Compound 3, half-maximal inhibitory concentration: 1800 nM
Compound 3: the middle estimate sits 5.0-fold (0.70 log units) above what was measured, outside the stated range (below it).
By their numbers in this assay, from the lowest: compounds 3 and 2 (each within the scatter of the next); then compound 1.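

In this assay, among these compounds, piperidin-1-yl in place of hydrogen on the saturated chain carbon, two bonds along the chain from a nitrogen on an aromatic ring, gives a 16-fold lower number from compound 1 to compound 3 (1.19 log units; beyond the scatter) and provides the first single-change step. This position therefore accepts a six-membered ring at the end of the chain, and the change from ethylamino to (2-(piperidin-1-yl)ethyl)amino is a large gain here. No supporting data bear on the origin of this gain.

Still open, going by these compounds, is whether a morpholine, a dimethylamino group or a carboxylic acid at the chain end would give a similar number. On these data alone, the effect of a longer chain between the amino nitrogen and the piperidine is also open.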